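A few compounds are considered here, and "the series" means these few. Any claim that something is new, unique, unknown or untested is made for them only; others in the source may bear on it.

In a functional assay on MCF7 cells (Homo sapiens) for inhibition, read by MTT assay, with a stated time of 72 h (on this read-out higher numbers stand for weaker inhibition and lower numbers for stronger inhibition), compound 1 `Nc1ccccc1NC(=O)c1ccc(CNC(=O)/C=C/c2cnc3ccccn23)cc1` gives 4130 nM, compound 2 `Nc1ccccc1NC(=O)c1ccc(CNC(=O)/C=C/c2c[nH]c3ccccc23)cc1` gives 2920 nM and compound 3 `Nc1ccccc1NC(=O)c1ccc(CNC(=O)/C=C/c2cnc3cccnn23)cc1` gives 2870 nM. Compound 3 therefore stands within the scatter of both other compounds, and no order can be drawn among the three.

The next comparison is with compound 4 `Cc1nc2ccccn2c1/C=C/C(=O)NCc1ccc(C(=O)Nc2ccccc2N)cc1`, and the change is a group of 10 heavy atoms (8 carbon, 2 nitrogen; one five-membered aromatic ring with 2 hetero atoms, one six-membered aromatic ring with 1 hetero atom) in place of a group of 9 heavy atoms (6 carbon, 3 nitrogen; one five-membered aromatic ring with 2 hetero atoms, one six-membered aromatic ring with 2 hetero atoms), on a double-bonded chain carbon bound to a double-bonded chain carbon. It lies on a double-bonded chain carbon bound to a double-bonded chain carbon. The entering group has one five-membered aromatic ring with 2 hetero atoms and one six-membered aromatic ring with 1 hetero atom, the same ring types as the group in compound 1.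

The measured exchanges at this place are a 1.4-fold lower number from compound 1 to compound 3 (0.16 log units; within the scatter), a 1.4-fold lower number from compound 1 to compound 2 (0.15 log units; within the scatter) and a 1.0-fold lower number from compound 2 to compound 3 (0.01 log units; within the scatter). All three stay within the scatter. For the measured compounds named here, none of the measured compounds carries a group of the entering size, so that part of the change is untested.

The expected change, a 1.1-fold higher number from compound 3 to compound 4 (0.06 log units; within the scatter), is no step beyond the scatter in this assay. For compound 4 the estimated value is 3300 nM, with an expected range of 1500 nM to 7500 nM.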

Compound 4, half-maximal inhibitory concentration: 6220 nM
Beside the measured number, compound 4's estimate is 1.9-fold (0.28 log units) below it; low and high end bracket the measured number.
By their numbers in this assay, from the lowest: compounds 3, 2, 1 and 4 (each within the scatter of the next, the first and the last beyond it).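

In this assay, exchanges at this place on the double-bonded chain carbon now go beyond the scatter, though only modestly (a 2.2-fold higher number from compound 3 to compound 4 (0.34 log units; beyond the scatter)) and (a 2.1-fold higher number from compound 2 to compound 4 (0.33 log units; beyond the scatter)). The narrowest change, methyl in place of hydrogen on an aromatic carbon, stays within the scatter (a 1.5-fold higher number from compound 1 to compound 4 (0.18 log units; within the scatter)), whereas the two larger steps combine that methyl with a change in the ring atoms, so the methyl alone accounts for no clear loss. No supporting data bear on the cause of this result.

As far as these compounds go, it remains open whether an ethyl group, a methoxy group or an amine on that aromatic carbon would shift the number beyond the scatter from compound 1. Also open, from the compounds shown here alone, is how a methyl group would behave on the ring groups of compound 2 and compound 3.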